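Shortening the Basic Side Chain in a Cytotoxic Series

A few compounds are considered here, and "the series" means these few. Any claim that something is new, unique, unknown or untested is made for them only; others in the source may bear on it.

Measured compounds:
compound 1, `CN(C)CCCCCn1c2c(c3ccccc31)C(=O)c1c[n+]([O-])c3ccccc3c1C2=O`, 240 nM
compound 2, `CCCCN1CCN(CCCCn2c3c(c4ccccc42)C(=O)c2c[n+]([O-])c4ccccc4c2C3=O)CC1`, 900 nM

Two compounds share the same core and differ only in the chain carried on the aromatic nitrogen. In a functional assay on MDA-MB-231 cells (Homo sapiens) for cytotoxicity, read by MTT assay, with a stated time of 72 h (a higher number here means a weaker inhibitor, a lower number a stronger inhibitor), compound 1 gives 240 nM, and compound 2 gives 900 nM, the highest of the two numbers. Within the data shown here, the one measured step, a 3.8-fold higher number from compound 1 to compound 2 (0.57 log units; beyond the scatter), came from 4-butylpiperazin-1-yl in place of (dimethylamino)methyl on a saturated chain carbon, four bonds along the chain from an aromatic nitrogen.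

Compound 3, `CN1CCN(CCCn2c3c(c4ccccc42)C(=O)c2c[n+]([O-])c4ccccc4c2C3=O)CC1`, has not yet been measured. Its change from compound 2 is 4-methylpiperazin-1-yl in place of (4-butylpiperazin-1-yl)methyl on a saturated chain carbon, three bonds along the chain from an aromatic nitrogen. Among the measured compounds shown here, the only step that bears on it, a 3.8-fold higher number from compound 1 to compound 2 (0.57 log units; beyond the scatter), shows that the smaller amine end of compound 1 went with the lower number, so a partial return toward that size is expected to give a modest move in the same direction. The expected step is a 1.8-fold lower number from compound 2 to compound 3 (0.26 log units; within the scatter), within or near the scatter. Compound 3 is therefore estimated at 500 nM, with a range from 200 nM to 1300 nM.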

Compound 3, half-maximal inhibitory concentration: 390 nM
Beside the measured number, compound 3's estimate is 1.3-fold (0.11 log units) above it; measured number inside the range.
By their numbers in this assay, from the lowest: compounds 1 and 3 (each within the scatter of the next); then compound 2.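

In this assay, replacing (4-butylpiperazin-1-yl)methyl with 4-methylpiperazin-1-yl on a saturated chain carbon, three bonds along the chain from an aromatic nitrogen, gives a 2.3-fold lower number from compound 2 to compound 3 (0.36 log units; beyond the scatter). The earlier pair could not show this: the six-membered ring with two hetero atoms is present in both compound 2 and compound 3, so the ring alone does not account for the higher number of compound 2, and a 1.6-fold higher number from compound 1 to compound 3 (0.21 log units; within the scatter) places a compound with this ring within the scatter of the dimethylamino compound. No measurement offered here explains either step, so these results describe only how the numbers move with the structures.

The change from compound 2 to compound 3 alters the chain and the group on the far piperazine nitrogen together, leaving open how much of the step belongs to each, which a 4-butylpiperazin-1-yl group on the chain of compound 3 would help to separate. Going by these compounds, it also remains open how other ring ends at this place, such as morpholin-4-yl or piperidin-1-yl, would stand in this assay, or how a longer chain ending in 4-methylpiperazin-1-yl would compare.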